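Adding an Amino Group Where the Sulfur Chain Sat

The source may hold more compounds than are shown below. What is called first, only, known or untested is meant among the compounds shown, and "the series" means these compounds.

Of the compounds shown here, three that share one core have been tested in a functional assay (spleen, spleen) for activation, with Mus musculus as the target; on this read-out lower numbers stand for an effect already at smaller amounts and higher numbers for an effect only at larger amounts of compound. Compound 1 `CCSc1nc(N)c2nc(O)n(Cc3ccccc3)c2n1` gives 0.1 uM. Compound 2 `CCCSc1nc(N)c2nc(O)n(Cc3ccccc3)c2n1` gives 0.01 uM, and a 10-fold lower number from compound 1 to compound 2 (1.00 log units; beyond the scatter). Compound 3 `Nc1ncnc2c1nc(O)n2Cc1ccccc1`, in which the carbon that carries the sulfur chain in the other two holds only a hydrogen, gives 10 uM, the highest number of the three: a 100-fold higher number from compound 1 to compound 3 (2.00 log units; beyond the scatter), and a 1000-fold higher number from compound 2 to compound 3 (3.00 log units; beyond the scatter).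

Compound 4 `Nc1nc(N)c2nc(O)n(Cc3ccccc3)c2n1` has not yet been measured in this assay. It differs from compound 3 in a single way: amino in place of hydrogen on an aromatic carbon. This is the same aromatic carbon that carries ethylsulfanyl in compound 1 and propylsulfanyl in compound 2.

The steps from compound 1 and compound 2 to compound 3 both bear on this change, and both were large: stripping that carbon down to hydrogen went with a much higher number. Going by the values given here, putting an amino group there may recover part of that, but an amino group is not a sulfur chain, and no measured pair shows what an amino group does at this position. A gain smaller than those two steps is therefore expected. Compound 4 is estimated to give 1 uM, with a range from 0.1 uM to 10 uM. The expected step is a 10-fold lower number from compound 3 to compound 4 (1.00 log units; beyond the scatter).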

Compound 4, minimum effective concentration: 10 uM
For compound 4 the middle estimate is 10-fold (1.00 log units) below the measured one; measured number inside the range.
By their numbers in this assay, from the lowest: compound 2; then compound 1; then compounds 3 and 4 (each within the scatter of the next).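

In this assay, placing an amino group on this aromatic carbon, between two ring nitrogen atoms, gives no change at the digits printed from compound 3 to compound 4 (within the scatter), so the data do not separate amino from plain hydrogen at this position. The earlier compounds shown here showed only that removing the sulfur chain raised the number, which left open whether any small group could stand in for it; amino does not, as the comparisons with the sulfur compounds give a 100-fold higher number from compound 1 to compound 4 (2.00 log units; beyond the scatter) and a 1000-fold higher number from compound 2 to compound 4 (3.00 log units; beyond the scatter). Nothing measured here gives a reason for this result.

The compounds shown leave open whether the sulfur atom itself matters or mainly the carbon chain attached to it, a question that a propoxy or propylamino group on the same carbon could help to settle. They also leave open whether the trend seen in a 10-fold lower number from compound 1 to compound 2 (1.00 log units; beyond the scatter) continues with a longer chain such as butylsulfanyl or pentylsulfanyl, or whether the number stops falling or rises again as the chain grows.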